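A Bromofuran in Place of a Pyrrole Ring

A few compounds are considered here, and "the series" means these few. Any claim that something is new, unique, unknown or untested is made for them only; others in the source may bear on it.

Compound 1 `COc1ccc(CNC(=O)/C(C#N)=C/c2ccc[nH]2)cc1` is one of three compounds tested in a functional assay on SMA cells (Homo sapiens) for inhibition, read by MTT assay, with a stated time of 72 h; a higher number here means a weaker inhibitor of growth, a lower number a stronger inhibitor of growth. For compound 1 the result is only a limit of the assay, > 50000 nM. Compound 2 `N#C/C(=C\c1ccc[nH]1)C(=O)NCc1ccc(Cl)c(Cl)c1` likewise reaches only a limit, > 50000 nM. Compound 3 `N#C/C(=C\c1ccco1)C(=O)NCc1ccc(Cl)c(Cl)c1` gives 38000 nM. Within the data shown here, the one measured step between close neighbours, an at least 1.3-fold lower number from compound 2 to compound 3 (0.11 log units; that floor lies within the scatter), is the nearest guide, and its floor lies within the scatter; the limit of > 50000 nM in this assay, at which 2 of the 3 values shown sit, keeps the true size of that step open. Compound 4 `COc1ccc(CNC(=O)/C(C#N)=C/c2ccc(Br)o2)cc1` differs from compound 1 by 5-bromofuran-2-yl in place of 1H-pyrrol-2-yl on a double-bonded chain carbon bound to a double-bonded chain carbon. A shift of similar kind, towards a lower number in this assay, is expected, though the limit for compound 1 leaves its size uncertain. Compound 4 is therefore estimated at 30000 nM, within 8000 nM to 60000 nM. The expected step is an at least 1.6-fold lower number from compound 1 to compound 4 (0.22 log units; that floor lies within the scatter).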

Compound 4, concentration for 50% growth inhibition: 14000 nM
For compound 4 the middle estimate is 2.1-fold (0.33 log units) above the measured one, within the range that was stated.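

Setting 5-bromofuran-2-yl in place of 1H-pyrrol-2-yl on a double-bonded chain carbon bound to a double-bonded chain carbon gives, in this assay, an at least 3.5-fold lower number from compound 1 to compound 4 (0.55 log units; beyond the scatter). The earlier furan step, an at least 1.3-fold lower number from compound 2 to compound 3 (0.11 log units; that floor lies within the scatter), could not be told from scatter, so this is the first change at this position shown to exceed it. Compound 1 stands at a limit, so the true size of the step stays open: the limit of > 50000 nM in this assay, at which 2 of the 4 values shown sit.

The compounds shown leave open whether the bromine or the furan ring accounts for the step. They also leave open whether a 5-chlorofuran-2-yl or 5-methylfuran-2-yl group would do the same.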